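A few compounds are considered here, and "the series" means these few. Any claim that something is new, unique, unknown or untested is made for them only; others in the source may bear on it.

Working notes on the series. Compound 1 `CCCCN(CC)c1cc(C)nc2c1NC(=O)CN2c1ccc(C(C)C)cc1Br` carries a butyl(ethyl)amino group on the shared core. Among the measured compounds shown here, in an assay on HEK-293T cells for displacement of a labelled ligand from corticotropin-releasing factor receptor 1 (Homo sapiens), read by scintillation counting, with a stated time of 2 h (a higher number here means a weaker inhibitor, a lower number a stronger inhibitor), compound 1 gives 2.4 nM, the lower-placed of the two numbers measured so far, though the gap to the other is inside the scatter. Compound 2 `CCCCN(CC)c1cc(C)nc2c1NC(=O)CN2c1ccc(C(C)(C)C)cc1Br` differs from compound 1 by methyl in place of hydrogen on a saturated chain carbon bound to an aromatic carbon and two saturated chain carbons, and in this assay compound 2 gives 4.2 nM; the step of a 1.8-fold higher number from compound 1 to compound 2 (0.24 log units; within the scatter) is within the scatter, so the two values are read as equal. Compound 3 `CCN(C)c1cc(C)nc2c1NC(=O)CN2c1ccc(C(C)C)cc1Br` is not yet measured. It differs from compound 1 by hydrogen in place of propyl on a saturated chain carbon bound to a nitrogen on an aromatic ring, that is, butyl to methyl, butyl(ethyl)amino to ethyl(methyl)amino. For the measured compounds named here, no measured step bears on this part of the molecule: the one step on record leaves the dialkylamino group untouched and gives no guide to its size. The expectation therefore rests on the structural change alone. Compound 3 is expected to come out weaker, the expected step being a 13-fold higher number from compound 1 to compound 3 (1.10 log units; beyond the scatter). For compound 3 the estimate in this assay is 30 nM, with a range from 6 nM to 150 nM.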

Compound 3, inhibition constant: 16.4 nM
For compound 3 the middle estimate is 1.8-fold (0.26 log units) above the measured one, within the range that was stated.
By their numbers in this assay, from the lowest: compounds 1 and 2 (each within the scatter of the next); then compound 3.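

Among the compounds shown here, the dialkylamino group is the first part of the molecule seen to move the number in this assay: hydrogen in place of propyl on a saturated chain carbon bound to a nitrogen on an aromatic ring gives a 6.8-fold higher number from compound 1 to compound 3 (0.83 log units; beyond the scatter), whereas the only earlier step, a 1.8-fold higher number from compound 1 to compound 2 (0.24 log units; within the scatter), changed another part of the molecule and stayed within the scatter. The change from butyl(ethyl)amino to ethyl(methyl)amino therefore registers in the read-out, yet the butyl chain is not required for a nanomolar value, since compound 3 gives 16.4 nM. Nothing on record accounts for the size of this step.

The compounds shown leave open how the number runs with other groups in place of butyl, such as a propyl chain, a longer chain such as pentyl, or a methoxyethyl group, since one step cannot separate a trend with chain length from an effect particular to this pair. Also open, as far as these compounds go, is whether the same change gives a step of similar size when it is made on compound 2, with its tert-butyl group.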